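Lengthening Methylamino to Ethylamino on a Shared Core

This account rests on a few compounds, and the source may have more. Where it says the series, first, only, none or still open, it means among the compounds named here.

In a functional assay on cells for positive allosteric modulation of G-protein coupled receptor 68 (Homo sapiens), read by a luciferase reporter and cAMP accumulation, with a stated time of 30 min, at pH 6.8 and pH 8.3, in the presence of a further agent that is not named here (a lower number here means a less potent compound, a higher number a more potent compound, by a factor of ten per unit of this negative logarithm), compound 1 `Nc1nc(NCc2ccccc2)nc(-c2ccccc2CO)n1` gives 4.35. Compound 2 `CNc1nc(NCc2ccccc2)nc(-c2ccccc2CO)n1` carries a methyl on one ring nitrogen in place of the hydrogen of compound 1. In this assay, among the compounds with values here, compound 2 gives 4.51 and stands at the upper end of the two numbers so far, separated from compound 1 by a step that is a number 0.16 log units higher from compound 1 to compound 2 (within the scatter).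

Compound 3 `CCNc1nc(NCc2ccccc2)nc(-c2ccccc2CO)n1` has not yet been measured in this assay. It differs from compound 2 by methyl in place of hydrogen on a saturated chain carbon bound to a nitrogen on an aromatic ring. Within the data shown here, the only measured step that bears on this change is a number 0.16 log units higher from compound 1 to compound 2 (within the scatter), which added a carbon at the neighbouring position and stayed inside the scatter. On that basis compound 3 is expected to show a step of a number 0.09 log units higher from compound 2 to compound 3 (within the scatter) in this assay, which is to say no change beyond the scatter. Compound 3 is therefore estimated at 4.6 in this assay, with a range from 4.2 to 5.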

Compound 3, negative logarithm of the antagonist equilibrium constant: 4.63
Estimate against measurement, compound 3: 0.03 log units below; measured number inside the range.
By their numbers in this assay, from the lowest: compounds 1, 2 and 3 (each within the scatter of the next).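

In this assay the change from methylamino to ethylamino gives a number 0.12 log units higher from compound 2 to compound 3 (within the scatter), so adding this carbon to the chain on the nitrogen does not separate the two compounds. Ethyl in place of hydrogen on the same nitrogen gives a number 0.28 log units higher from compound 1 to compound 3 (within the scatter), which means that even the full change from hydrogen to ethyl stays inside the scatter, and hydrogen, methyl and ethyl cannot be told apart at this position in these three compounds. Nothing available here offers an explanation for this result. What the compounds shown leave open is whether a longer chain such as propyl or butyl, or a branched group such as isopropyl, would give a number beyond the scatter. As far as these compounds go, it also remains open how a carboxylic acid or a further amine at the end of the chain would read.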